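This account rests on a few compounds, and the source may have more. Where it says the series, first, only, none or still open, it means among the compounds named here.

Of the compounds shown here, two built on the same core have been tested for their ability to slow the growth of colon cancer cells in a functional assay on HCT-116 cells (Homo sapiens) for antiproliferative activity, read by MTT assay, with a stated time of 48 h; on this read-out lower numbers stand for stronger inhibition and higher numbers for weaker inhibition. Compound 1 `COc1cc(/C=C/C(C)=O)ccc1OCc1cn(-c2ccc(/N=N/c3ccccc3)cc2)nn1` gave no number in this assay: its result, > 100000 nM, is a limit of the measurement. Compound 2 `COc1cc(/C=C/C(C)=O)ccc1OCc1cn(-c2c(Cl)cccc2Cl)nn1` gives 2000 nM in this assay. Among the measured compounds shown here, that makes compound 2 the holder of the only real number in the set, because the other value sits at the limit of > 100000 nM in this assay, at which 1 of the 2 values shown sits. The next compound, compound 3 `COc1cc(/C=C/C(C)=O)ccc1OCc1cn(-c2ccc([N+](=O)[O-])cc2)nn1`, keeps the whole of compound 2 except for the group attached to the aromatic nitrogen of the five-membered ring: 4-nitrophenyl in place of 2,6-dichlorophenyl on an aromatic nitrogen. For the measured compounds named here, no measured pair of compounds differing in a single place exists here, so the size of the effect of this change cannot be read from the data. The expectation is a loss of potency from compound 2 to compound 3 of about a 4.0-fold higher number from compound 2 to compound 3 (0.60 log units; beyond the scatter), a step beyond the usual scatter. Compound 3 is therefore estimated at 8000 nM in this assay, with a plausible range from 2000 nM to 40000 nM.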

Compound 3, half-maximal inhibitory concentration: 96300 nM
Compound 3: the middle estimate sits 12-fold (1.08 log units) below what was measured; the measured number lies above the stated range.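

Among the compounds shown here, the aromatic nitrogen of the five-membered ring, for which no measured pair existed before, now proves to be a place where one change matters greatly in this assay: 4-nitrophenyl in place of 2,6-dichlorophenyl gives a 48-fold higher number from compound 2 to compound 3 (1.68 log units; beyond the scatter) in a single swap. The other comparison, a change on an aromatic carbon, gives an at least 1.0-fold lower number from compound 1 to compound 3 (0.01 log units; that floor lies within the scatter) and so shows no difference that can be told from the scatter. The result for compound 1 is a limit and not a number, which leaves that comparison with only a floor: the limit of > 100000 nM in this assay, at which 1 of the 3 values shown sits.

This swap removes the chlorine atoms and brings in a nitro group at the same time, and the compounds shown do not separate these two parts, so the large loss cannot yet be assigned to either of them, nor can any cause be read from these values. An unsubstituted phenyl, a 4-chlorophenyl or a 4-aminophenyl on the same aromatic nitrogen would help to show which part of the change carries the loss and whether any group there can match 2,6-dichlorophenyl.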